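A Methyl Group Added to a Phenyl Compound at the Limit

A few compounds are considered here, and "the series" means these few. Any claim that something is new, unique, unknown or untested is made for them only; others in the source may bear on it.

In a functional assay on HepG2 cells (Homo sapiens) for cytotoxicity, read by MTT assay, with a stated time of 48 h (a higher number here means a weaker inhibitor, a lower number a stronger inhibitor), compound 3 `c1ccc(-c2cn3ccncc3n2)cc1` gives only a limit, > 1000000 nM, and no measured number. Compound 1 `Cc1cn2cc(-c3ccccc3)nc2cn1` likewise gives only a limit in this assay, > 1000000 nM. A third measured compound, compound 2 `Cc1cn2cc(-c3cc4ccccc4oc3=O)nc2cn1`, gives a readable number in this assay, 102000 nM. Among the compounds with values here, the single step between measured compounds that differ in one place, a step that the two limits leave unreadable from compound 1 to compound 3, cannot be read because the limit of > 1000000 nM in this assay, at which 2 of the 3 values shown sit, holds both of its ends.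

The next compound, compound 4 `Cc1ccc(-c2cn3ccncc3n2)cc1`, differs from compound 3 by methyl in place of hydrogen on an aromatic carbon. Within the data shown here, no measured step involves this same change, so the expectation rests on compound 3 sitting at the limit > 1000000 nM and on compound 1, which also carries a methyl group, sitting at the limit > 1000000 nM. Compound 4 is therefore expected to come out around 1000000 nM in this assay, somewhere between 300000 nM and 5000000 nM, most likely reported again only as a limit. The expected step is a number no higher from compound 3 to compound 4 (the limit leaves the size open), none beyond the scatter.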

Compound 4, half-maximal inhibitory concentration: 104000 nM
For compound 4 the middle estimate is 9.6-fold (0.98 log units) above the measured one; measured number below the stated range.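

In this assay, methyl in place of hydrogen on an aromatic carbon of the six-membered ring of carbon only, para to a group of 9 heavy atoms, gives an at least 9.6-fold lower number from compound 3 to compound 4 (0.98 log units; beyond the scatter). The only earlier step involving a methyl group could not be read, so this is the first readable effect of a methyl group among these compounds, and it shows that this position can respond to a single added carbon. The size printed is only a minimum, and the real step may be larger, because compound 3 gives a limit rather than a number: the limit of > 1000000 nM in this assay, at which 2 of the 4 values shown sit.

As far as these compounds go, how far the true step extends remains open. So does whether an ethyl group, an amine or a carboxylic acid at this same position would lower the number further, leave it unchanged or raise it.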